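This account rests on a few compounds, and the source may have more. Where it says the series, first, only, none or still open, it means among the compounds named here.

Working notes on the series.

Of the compounds shown here, three have been measured so far in a physicochemical assay, with a stated time of 30 min; a higher number here means that more compound is needed for the effect, a lower number that less compound is needed. Compound 1 `COc1cc(/C=C/C(=O)O[C@H]2[C@H](OC[C@H]3O[C@@H](Oc4cc5c(cc4O)C[C@@H](C(=O)O)N5C(=O)/C=C/c4ccc(O)c(OC)c4)[C@H](O)[C@@H](O)[C@@H]3O)O[C@H](CO)[C@@H](O)[C@@H]2O)ccc1O` gives 27600 nM. Compound 2 `COc1cc(/C=C/C(=O)N2c3cc(O[C@@H]4O[C@H](CO)[C@@H](O)[C@H](O)[C@H]4O)c(O)cc3C[C@H]2C(=O)O)ccc1O` gives 35200 nM. Compound 3 `COc1cc(/C=C/C(=O)N2c3cc(O[C@@H]4O[C@H](CO[C@@H]5O[C@H](CO)[C@@H](O)[C@H](O)[C@H]5O)[C@@H](O)[C@H](O)[C@H]4O)c(O)cc3C[C@H]2C(=O)O)ccc1O[C@@H]1O[C@H](CO)[C@@H](O)[C@H](O)[C@H]1O` gives 40900 nM. Compound 3 thus carries the highest of the three numbers, but its gap to compound 2 and its gap to compound 1 both lie within the usual scatter of this assay, so the three measured compounds cannot be told apart on the numbers alone, and no ordering among them is claimed.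

The next compound to be measured is compound 4 `COc1cc(/C=C/C(=O)N2c3cc(O[C@@H]4O[C@H](CO[C@@H]5O[C@H](CO)[C@@H](O)[C@H](O)[C@H]5O)[C@@H](O)[C@H](O)[C@H]4O)c(O)cc3C[C@H]2C(=O)O)ccc1O`. It differs from compound 3 in one place: hydrogen in place of 3,4,5-trihydroxy-6-(hydroxymethyl)oxan-2-yl on an oxygen on an aromatic ring. The remaining part of the structure, including the shared core of compound 3 and its other substituents, is unchanged.

Among the compounds with values here, no pair of measured compounds differs in exactly one place, so no step of a single change is available to carry over. The three measured values sit inside one band of scatter regardless of how the sugar-bearing parts are arranged, and the change at hand removes one such part. On that basis no step beyond the scatter is expected from compound 3 to compound 4 in this assay, so that the expected step reads a 1.1-fold lower number from compound 3 to compound 4 (0.04 log units; within the scatter). Compound 4 is therefore expected to give about 37000 nM in this assay, with a range from 18000 nM to 75000 nM.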

Compound 4, half-maximal effective concentration: 40100 nM
Compound 4: the middle estimate sits 1.1-fold (0.03 log units) below what was measured; measured number inside the range.
By their numbers in this assay, from the lowest: compounds 1, 2, 4 and 3 (each within the scatter of the next).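

In this assay, within the data shown here, the first single-change step at this position puts hydrogen in place of 3,4,5-trihydroxy-6-(hydroxymethyl)oxan-2-yl on an oxygen on an aromatic ring and reads a 1.0-fold lower number from compound 3 to compound 4 (0.01 log units; within the scatter), so in this pair the group can be exchanged for hydrogen at this place without a step beyond the scatter. The same group, put in place of hydrogen on an oxygen on a saturated carbon, gives a 1.1-fold higher number from compound 2 to compound 4 (0.06 log units; within the scatter), so the two single-change steps now available, at two different places, both stay inside the scatter. No accompanying measurement bears on this result or offers an explanation for it.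

On these data alone, these two steps cover only hydrogen and this one sugar group, and whether a methyl group or a longer chain on the same oxygen on an aromatic ring, or an amine or a carboxylic acid at that place, would give a step beyond the scatter remains open. Also open, as far as these compounds go, is whether the absence of a readable step holds for a compound outside this small set, since every reading here comes from this assay alone.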